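A Dimethoxyphenyl Swap at the Far End of Compound 2

The source may report more compounds than this note shows. Statements on the series, on what has been measured and on what is new or still open speak of the compounds shown alone.

Compound 1 `FC(F)(F)Oc1ccc(-c2ccc(-c3ccc(-c4nc5ccccc5[nH]4)cc3)cc2)cc1`: 38400 nM
Compound 2 `Oc1cccc2[nH]c(-c3ccc(-c4ccc(-c5ccc(OC(F)(F)F)cc5)cc4)cc3)nc12`: 2210 nM

Among the measured compounds shown here, in a functional assay on MCF7 cells (Homo sapiens) for inhibition, read by sulforhodamine B assay (a lower number here means a stronger inhibitor of growth, a higher number a weaker inhibitor of growth), compound 1 gives 38400 nM and compound 2 gives 2210 nM; the one measured step is a 17-fold lower number from compound 1 to compound 2 (1.24 log units; beyond the scatter). Compound 2 thus holds the lowest of the two numbers shown. Compound 3 `COc1ccc(-c2ccc(-c3ccc(-c4nc5c(O)cccc5[nH]4)cc3)cc2)cc1OC` differs from compound 2 by 3,4-dimethoxyphenyl in place of 4-(trifluoromethoxy)phenyl on an aromatic carbon. For the measured compounds named here, the measured step alters a different part of the shared core, so no measured step bears on this change, and the data give no guide to its direction. A step within the scatter is expected in this assay, a 1.4-fold higher number from compound 2 to compound 3 (0.13 log units; within the scatter). Compound 3 is estimated at 3000 nM, between 800 nM and 12000 nM.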

Compound 3, concentration for 50% growth inhibition: 190 nM
For compound 3 the middle estimate is 16-fold (1.20 log units) above the measured one; measured number below the stated range.
By their numbers in this assay, from the lowest: compound 3; then compound 2; then compound 1.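

The outer aromatic ring of the shared core, untouched by the earlier step, proves to be a position where a single change moves the number strongly in this assay. Replacing 4-(trifluoromethoxy)phenyl with 3,4-dimethoxyphenyl gives a 12-fold lower number from compound 2 to compound 3 (1.07 log units; beyond the scatter), so this position can lower the number with the hydroxy group already in place. Nothing available explains why this change has this effect.

As far as these compounds go, it remains open whether this step depends on that hydroxy group, and whether both methoxy groups are needed. Also open, from the compounds shown here alone, is how an amine or a carboxylic acid on this ring would compare.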